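The compounds below may be only part of what the source reports. "The series", "measured", "known", "first", "only" and "open" are said of these compounds alone.

Measured in a functional assay on the whole organism (strain CF-1) with Mus musculus as the target, in the writhing test, with a stated time of 15 min; a higher number here means that more compound is needed for the effect, a lower number that less compound is needed:
compound 1 `CC(=O)/N=C1\NC2(CCCCO2)CCS1` — 3.1 mg/kg
compound 2 `O=C(/N=C1\NC2(CCCCO2)CCS1)c1ccccc1` — 5 mg/kg
compound 3 `O=C(/N=C1\NC2(CCCCO2)CCS1)c1ccc(F)cc1` — 8.8 mg/kg; 28 mg/kg; 49 mg/kg (3 entries)

Within the data shown here, compound 2 holds the higher of the two single numbers in this assay; its only measured neighbour is compound 1, and that step, a 1.6-fold higher number from compound 1 to compound 2 (0.21 log units; within the scatter), lies within the scatter. Compound 3, which carries fluorine on the same ring, has only a spread of entries, (the several entries of compound 3 in this assay, 8.8 mg/kg; 28 mg/kg; 49 mg/kg (3 entries)), all of them above the number of compound 2.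

Compound 4 `O=C(/N=C1\NC2(CCCCO2)CCS1)c1cccc(C(F)(F)F)c1` is compound 2 with trifluoromethyl in place of hydrogen on an aromatic carbon. Among the measured compounds shown here, no measured step covers substitution on this ring; the only evidence is the spread of compound 3, which points towards a higher number after adding a group to the ring. The expected step is a 2.4-fold higher number from compound 2 to compound 4 (0.38 log units; beyond the scatter). Compound 4 is thus estimated at 12 mg/kg, range 4 mg/kg to 40 mg/kg.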

Compound 4, dose for half-maximal effect: > 200 mg/kg
Compound 4: a limit, no number (the forecaster's own chance of this, stated with the estimate: 10%); middle value at least 16-fold (1.22 log units) from the limit.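

In this assay compound 4 gives > 200 mg/kg, which is a limit and not a number. Trifluoromethyl on an aromatic carbon, meta to a large group, gives an at least 40-fold higher number from compound 2 to compound 4 (1.60 log units; beyond the scatter), so this ring position does not tolerate every change in this assay. Compound 3, the only other compound substituted on this ring, offers no single number for comparison: the several entries of compound 3 in this assay, 8.8 mg/kg; 28 mg/kg; 49 mg/kg (3 entries)

The compounds shown leave open whether the loss belongs to trifluoromethyl itself or to this place on the ring. Chlorine or a methoxy group on the same aromatic carbon would separate the two.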